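Carbamoyl-linked piperidine on the compound 2 scaffold

The source may hold more compounds than are shown below. What is called first, only, known or untested is meant among the compounds shown, and "the series" means these compounds.

Going by the values given here, in an assay on isolated protein for inhibition of serine/threonine-protein kinase PLK1 (Homo sapiens), read by Z'-LYTE, with a stated time of 60 min (on this read-out lower numbers stand for stronger inhibition and higher numbers for weaker inhibition), compound 1 `CCOc1cc(C2CCN(C)CC2)ccc1Nc1ncc2c(n1)N(Cc1sccc1C)[C@H](CC)C(=O)N2C` gives 68 nM and compound 2 `CCOc1cc(C2CCN(C)CC2)ccc1Nc1ncc2c(n1)N(Cc1cccc(Br)c1)[C@H](CC)C(=O)N2C` gives 540 nM; the only measured change is a 7.9-fold higher number from compound 1 to compound 2 (0.90 log units; beyond the scatter). Compound 2 thus holds the highest number of the two measured. Compound 3 `CCOc1cc(C(=O)NC2CCN(C)CC2)ccc1Nc1ncc2c(n1)N(Cc1cccc(Br)c1)[C@H](CC)C(=O)N2C` carries (1-methylpiperidin-4-yl)carbamoyl in place of 1-methylpiperidin-4-yl on an aromatic carbon. Among the compounds with values here, no measured step touches this change; the single step concerns a different part of the shared core and gives no guide to direction or size here. The expected step is a 1.1-fold lower number from compound 2 to compound 3 (0.03 log units; within the scatter), none beyond the scatter. Compound 3 is therefore estimated at 500 nM, with a range of 150 nM to 1700 nM.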

Compound 3, half-maximal inhibitory concentration: 110 nM
Compound 3: the middle estimate sits 4.5-fold (0.66 log units) above what was measured; measured number below the stated range.
By their numbers in this assay, from the lowest: compounds 1 and 3 (each within the scatter of the next); then compound 2.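

In this assay, the aromatic carbon meta to an ethoxy group is sensitive to the group it carries: (1-methylpiperidin-4-yl)carbamoyl in place of 1-methylpiperidin-4-yl gives a 4.9-fold lower number from compound 2 to compound 3 (0.69 log units; beyond the scatter). Going by these compounds alone, this is the first reading at this position, since the earlier step concerned a different part of the molecule, and it rests on the 3-bromophenyl series alone. No measured evidence explains the change.

On these data alone, it remains open whether the same step holds with the 3-methylthiophen-2-yl group of compound 1. As far as these compounds go, it is also open whether the carbonyl, the amide hydrogen or the piperidine ring matters most, which a morpholine-4-carbonyl group at this carbon could begin to separate.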